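Adding a methyl on the hydrazide chain of a bromophenyl analogue

The compounds below may be only part of what the source reports. "The series", "measured", "known", "first", "only" and "open" are said of these compounds alone.

The study covers four compounds that share one core and differ in two places. Compound 1 `CC(=O)NNC(=O)c1csc2ncc(-c3ccc(C)cc3)n12` carries a 4-methylphenyl group and an acetyl end on its hydrazide. Compound 2 `CCC(=O)NNC(=O)c1csc2ncc(-c3ccc(C)cc3)n12` keeps the 4-methylphenyl group but has a propanoyl end. Compound 3 `CC(=O)NNC(=O)c1csc2ncc(-c3ccc(Br)cc3)n12` returns to the acetyl end and carries a 4-bromophenyl group. Compound 4 `CCC(=O)NNC(=O)c1csc2ncc(-c3ccc(Br)cc3)n12` combines the propanoyl end with the 4-bromophenyl group.

In a functional assay on MCF7 cells (Homo sapiens) for antiproliferative activity, read by MTT assay, with a stated time of 72 h (a higher number here means a weaker inhibitor, a lower number a stronger inhibitor), compound 1 gives 57300 nM, compound 2 gives 5190 nM and compound 3 gives 1830 nM. The change from compound 1 to compound 2, (methyl in place of hydrogen on a saturated chain carbon bound to a carbonyl carbon), gives an 11-fold lower number from compound 1 to compound 2 (1.04 log units; beyond the scatter). The cores of compound 1 and compound 3 differ by bromo in place of methyl on an aromatic carbon, which gives a 31-fold lower number from compound 1 to compound 3 (1.50 log units; beyond the scatter). Compound 3 thus stands lowest of the three measured values.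

The change from compound 3 to compound 4 is methyl in place of hydrogen on a saturated chain carbon bound to a carbonyl carbon, the same change as from compound 1 to compound 2, made on the 4-bromophenyl core. For the measured compounds named here, because the earlier step is an 11-fold lower number from compound 1 to compound 2 (1.04 log units; beyond the scatter), the step from compound 3 to compound 4 is expected to run in the same direction, though with only one earlier instance its size is less certain, and compound 4 is expected to show a 6.1-fold lower number from compound 3 to compound 4 (0.79 log units; beyond the scatter) in this assay. Compound 4 is therefore estimated at 300 nM, with the range 80 nM to 1200 nM.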

Compound 4, half-maximal inhibitory concentration: 15000 nM
Beside the measured number, compound 4's estimate is 50-fold (1.70 log units) below it, and the stated range ends below it.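

In this assay, adding the methyl to the acetyl end on the 4-bromophenyl core gives an 8.2-fold higher number from compound 3 to compound 4 (0.91 log units; beyond the scatter), so the change that lowered the number on the 4-methylphenyl core raises it here, and the two instances disagree in direction: the same change on two cores in this assay, an 11-fold lower number (1.04 log units; beyond the scatter) from compound 1 to compound 2 and an 8.2-fold higher number (0.91 log units; beyond the scatter) from compound 3 to compound 4, 90-fold (1.96 log units) apart, beyond the scatter of two such steps. The exchange of methyl for bromo on the aromatic carbon does not carry over either, giving a 2.9-fold higher number from compound 2 to compound 4 (0.46 log units; beyond the scatter) with the propanoyl end, the opposite direction to the step seen with the acetyl end: the same change on two cores in this assay, a 31-fold lower number (1.50 log units; beyond the scatter) from compound 1 to compound 3 and a 2.9-fold higher number (0.46 log units; beyond the scatter) from compound 2 to compound 4, 90-fold (1.96 log units) apart, beyond the scatter of two such steps. Within these four compounds, the result of a change in one place therefore depends on what sits in the other, so neither step can be carried unchanged from one core to another, but the data do not show the reason for this dependence or whether it extends beyond these two hydrazide ends and two aryl groups.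

The compounds shown leave open how a longer chain, such as a butanoyl end, would behave on either core, and whether a chlorophenyl group would follow the 4-methylphenyl or the 4-bromophenyl pair. They also leave open what an amine or a carboxylic acid at the end of the hydrazide chain would do to the number on each core.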